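This account rests on a few compounds, and the source may have more. Where it says the series, first, only, none or still open, it means among the compounds named here.

Compound 1 `C#Cc1ncccn1`: in a functional assay on NCI-H522 cells (Homo sapiens) for cytotoxicity, with a stated time of 3 days (on this read-out higher numbers stand for weaker inhibition and lower numbers for stronger inhibition), compound 1 gives > 40000 nM, which is a limit of the assay rather than a number.
Compound 2 `Ic1nc2ccccc2[se]1`: compound 2 gives > 40000 nM, again a limit and not a number.
Compound 3 `C=Cc1nc2ccccc2n1C`: compound 3 gives 2340 nM.

Among these three results, compound 3 stands alone as the only actual number in this assay; the other two results are limits, as the limit of > 40000 nM in this assay, at which 2 of the 3 values shown sit, records. Nothing more can be said of how compound 3 compares with compounds 1 and 2 than that their values are limits while its own is a measured figure.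

Compound 4 `Cn1c(Br)nc2ccccc21` has not yet been measured in this assay. It differs from compound 3 in one place: bromo in place of vinyl on an aromatic carbon. The shared core of compounds 3 and 4 is the same, and the methyl group stays where it is.

For the measured compounds named here, with no measured pair of compounds differing in a single place, there is no step to lean on. The change is small in size, so the step of a 1.5-fold higher number from compound 3 to compound 4 (0.17 log units; within the scatter) is expected to be modest, leaning toward weaker inhibition but not clearly beyond the usual scatter. Compound 4 is expected to give about 3500 nM, with a plausible range from 1000 nM to 15000 nM.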

Compound 4, half-maximal inhibitory concentration: > 40000 nM
Compound 4 gave a limit, no number; the forecaster's own chance of this, stated with the estimate: 12%; at least 11-fold (1.05 log units) between middle value and limit.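

This is the first change in a single place among the compounds shown, and in this assay it gives an at least 17-fold higher number from compound 3 to compound 4 (1.23 log units; beyond the scatter), so bromo in place of vinyl on this aromatic carbon, between two ring nitrogen atoms, is far from a neutral swap. The result for compound 4 is a limit and not a number, and it joins the earlier limits in the set: the limit of > 40000 nM in this assay, at which 3 of the 4 values shown sit. Within this one pair, a measured number appears only with vinyl in place, a group of two carbon atoms with a double bond, and not with the single bromine atom.

One pair cannot tell whether the double bond of vinyl matters or only the presence of a carbon group at this place, and an ethyl group, a longer chain or an amine on the same carbon would be needed to separate these possibilities. What the methyl group on the neighbouring ring atom contributes also stays open, as no pair shown changes that group while keeping the vinyl.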